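The compounds below may be only part of what the source reports. "The series", "measured", "known", "first", "only" and "open" are said of these compounds alone.

Compound 2 `CCOC(=O)N1CCCc2cc(S(=O)(=O)N3CC(c4ccccc4)NC3=O)ccc21` shares its core with compound 1 `O=C1NC(c2ccccc2)CN1S(=O)(=O)c1ccc2c(c1)CCCN2` and compound 3 `CCCCOC(=O)N1CCCc2cc(S(=O)(=O)N3CC(c4ccccc4)NC3=O)ccc21`. In a functional assay on cells (KATO III cell, Homo sapiens) for antiproliferative activity, read by MTT assay (a higher number here means a weaker inhibitor, a lower number a stronger inhibitor), compound 2 gives 11200 nM, the higher of the two plain numbers, while compound 3 gives 4010 nM. Compound 1 reaches only a limit of this assay, > 20000 nM. The steps of an at least 1.7-fold lower number from compound 1 to compound 2 (0.25 log units; that floor lies within the scatter) and an at least 4.9-fold lower number from compound 1 to compound 3 (0.69 log units; beyond the scatter) point the same way, and a 2.8-fold lower number from compound 2 to compound 3 (0.45 log units; beyond the scatter) lowers the number further. Compound 4 `O=C(CCl)NC(=O)N1CCCc2cc(S(=O)(=O)N3CC(c4ccccc4)NC3=O)ccc21` differs from compound 2 by ((chloromethyl)carbonyl)amino in place of ethoxy on a carbonyl carbon. Among the compounds with values here, no measured step covers a group of this kind, so only a modest move towards a lower number is expected, as in the step of a 1.9-fold lower number from compound 2 to compound 4 (0.27 log units; within the scatter). Compound 4 is therefore estimated at 6000 nM, with a range from 1500 nM to 25000 nM.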

Compound 4, half-maximal inhibitory concentration: 2540 nM
Compound 4: middle estimate off by 2.4-fold (0.37 log units), on the high side; low and high end bracket the measured number.
By their numbers in this assay, from the lowest: compounds 4 and 3 (each within the scatter of the next); then compound 2. At a limit, above all of these: compound 1.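

Replacing ethoxy on the carbonyl carbon with ((chloromethyl)carbonyl)amino, which brings a hydrogen-bond donor, gives a 4.4-fold lower number from compound 2 to compound 4 (0.64 log units; beyond the scatter) in this assay, so this place accepts more than simple alkoxy groups. Against butoxy, the new group shows a 1.6-fold lower number from compound 3 to compound 4 (0.20 log units; within the scatter) and cannot be ranked apart from it. Compound 1 stands at a limit, so an at least 7.8-fold lower number from compound 1 to compound 4 (0.89 log units; beyond the scatter) gives only a floor: the limit of > 20000 nM in this assay, at which 1 of the 4 values shown sits.

On these data alone, what the chlorine contributes stays open. Answering that would take the same group with methyl in place of chloromethyl, or a simple amine on the carbonyl carbon.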